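The source may hold more compounds than are shown below. What is called first, only, known or untested is meant among the compounds shown, and "the series" means these compounds.

In an ADME assay on microsomes from liver (Mus musculus) for metabolic stability, read by mass spectrometry, using NADPH, tested at 1.5 uM (on this read-out higher numbers stand for a longer-lived compound and lower numbers for a shorter-lived compound), compound 1 (`O=C(Nc1ccc2sc(-c3ccccc3)nc2c1)N1CCCCC1`) gives 0.283 h and compound 2 (`O=C(Nc1ccc2sc(-c3ccc(F)c(F)c3)nc2c1)N1CCCC1`) gives 0.233 h. Among the compounds with values here, these two values lie within the usual scatter of each other, so compound 2 stands level with compound 1, the only other compound measured. Within the data shown here, the two compounds differ in more than one place, so no single-change step is available as a guide. Compound 3 (`O=C(Nc1ccc2sc(-c3cccc(F)c3)nc2c1)N1CCCC1`) carries 3-fluorophenyl where compound 2 carries 3,4-difluorophenyl: hydrogen in place of fluoro on an aromatic carbon, with hydrogen in place of fluoro on an aromatic carbon. No shift beyond the scatter is expected in this assay, and any drift could go either way. The expected change, a 1.1-fold lower number from compound 2 to compound 3 (0.02 log units; within the scatter), is therefore small. The half-life of compound 3 is estimated at 0.22 h, with an expected range of 0.12 h to 0.4 h.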

Compound 3, half-life: 0.2 h
Estimate against measurement, compound 3: 1.1-fold (0.04 log units) above; the range from low to high includes it.
By their numbers in this assay, from the lowest: compounds 3, 2 and 1 (each within the scatter of the next).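

In this assay, the step from the 3,4-difluorophenyl to the 3-fluorophenyl group gives a 1.2-fold lower number from compound 2 to compound 3 (0.07 log units; within the scatter). Within the data shown here, this is the first single-place comparison in the set, and it shows that losing the fluoro group from this aromatic carbon, ortho to a fluoro group and para to a large group, does not separate the two compounds on half-life. No measurement available here accounts for this result.

Among these compounds, what the remaining fluoro group contributes stays open, as compound 1, the only compound with an unsubstituted phenyl, differs from compound 3 in more than one place. Going by these compounds, it is also open whether a larger group at this carbon, such as methoxy, trifluoromethyl or an amine, would move the half-life beyond the scatter.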